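Changing the Group on the Carbonyl Carbon of Compound 1

A few compounds are considered here, and "the series" means these few. Any claim that something is new, unique, unknown or untested is made for them only; others in the source may bear on it.

Compound 1 `Cn1cccc1C(=O)/C=C/c1ccc2c(c1)B(O)OC2`: 93600 nM
Compound 2 `CCc1ccc(C(=O)/C=C/c2ccc3c(c2)B(O)OC3)cc1`: 4400 nM
Compound 3 `O=C(/C=C/c1ccc2c(c1)B(O)OC2)c1ccc(O)c(O)c1`: only a limit was reached, > 100000 nM

All three share one core and differ only in the group on the carbonyl carbon. In a functional assay on SK-OV-3 cells (Homo sapiens) for cytotoxicity, read by MTT assay, with a stated time of 48 h (on this read-out higher numbers stand for weaker inhibition and lower numbers for stronger inhibition), compound 1 gives 93600 nM, the highest of the two numbers; compound 2 gives a far lower number. One of the three values is a limit: the limit of > 100000 nM in this assay, at which 1 of the 3 values shown sits.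

Going by the values given here, compound 4 `Nc1cccc(C(=O)/C=C/c2ccc3c(c2)B(O)OC3)c1` has not been measured. 3-aminophenyl in place of 1-methyl-1H-pyrrol-2-yl on a carbonyl carbon No measured pair shows this step. In this assay a moderate step toward a lower number is expected, since compound 2 with a six-membered aromatic ring of carbon only on the carbonyl carbon gives 4400 nM. Compound 4 is expected near 30000 nM, within 8000 nM to 100000 nM. The expected step is a 3.1-fold lower number from compound 1 to compound 4 (0.49 log units; beyond the scatter).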

Compound 4, half-maximal inhibitory concentration: 7400 nM
For compound 4 the middle estimate is 4.1-fold (0.61 log units) above the measured one; the measured number lies below the stated range.
By their numbers in this assay, from the lowest: compounds 2 and 4 (each within the scatter of the next); then compound 1. At a limit, above all of these: compound 3.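

Replacing the group on the carbonyl carbon gives a 13-fold lower number from compound 1 to compound 4 (1.10 log units; beyond the scatter) in this assay, so a large drop at this position does not depend on the ethyl-bearing ring of compound 2. Compound 4 and compound 2 lie within the scatter of each other, which puts a second six-membered aromatic ring of carbon only in that range. Compound 3 also carries such a ring and goes against any simple rule; its value is a limit (> 100000 nM).

Nothing measured here gives a reason for the step. Going by these compounds, whether a carboxylic acid or a longer chain in place of the amine of compound 4 would stay in that range remains open.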